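The compounds below may be only part of what the source reports. "The series", "measured", "known", "first", "only" and "open" are said of these compounds alone.

Measured compounds:
compound 1, `COc1cccc(C(=O)N[C@@H](CCC2CCCCC2)C(=O)N[C@@H](CC(C)C)CN2CCc3cc(F)ccc32)c1`, with 28 nM in an assay on isolated protein for inhibition of cathepsin S (Homo sapiens); a lower number here means a stronger inhibitor, a higher number a weaker inhibitor;
compound 2, `COc1cccc(C(=O)N[C@@H](CCC2CCCCC2)C(=O)N[C@H](CN2CCc3cc(F)ccc32)[C@@H](C)O)c1`, with 8 nM in this assay.

Of the two numbers, compound 2 stands at the lower one: the step of a 3.5-fold lower number from compound 1 to compound 2 (0.54 log units; beyond the scatter) lies beyond the scatter, so compound 2 is the stronger inhibitor of the pair.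

Compound 3, `COc1cccc(C(=O)N[C@@H](CCC2CCCCC2)C(=O)N[C@@H](CCCN)CN2CCc3cc(F)ccc32)c1`, has not been measured. It differs from compound 2 in one place: 3-aminopropyl in place of 1-hydroxyethyl on a saturated chain carbon bound to an amide-type nitrogen and a saturated chain carbon.

Going by the values given here, only one measured step exists here, and it concerns a different exchange at the same place: from compound 1 to compound 2 the group on that carbon changed from isobutyl to 1-hydroxyethyl, which gave a 3.5-fold lower number from compound 1 to compound 2 (0.54 log units; beyond the scatter). Nothing measured shows what a 3-aminopropyl group does at this position, so the step of a 1.9-fold higher number from compound 2 to compound 3 (0.27 log units; within the scatter) from compound 2 to compound 3 is only an expectation, and a modest one in either direction is as likely as none beyond the scatter. Compound 3 is therefore estimated at 15 nM in this assay, with a range from 4 nM to 60 nM.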

Compound 3, inhibition constant: 76 nM
The estimate for compound 3 lay 5.1-fold (0.70 log units) below the measured number, and the stated range ends below it.
By their numbers in this assay, from the lowest: compound 2; then compound 1; then compound 3.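

In this assay, the position proves able to lose as well as gain: 3-aminopropyl in place of 1-hydroxyethyl on this saturated chain carbon gives a 9.5-fold higher number from compound 2 to compound 3 (0.98 log units; beyond the scatter), whereas the earlier compounds had shown only a gain. The amine-bearing chain also falls behind the isobutyl group of compound 1, with a 2.7-fold higher number from compound 1 to compound 3 (0.43 log units; beyond the scatter), so the side chains now stand in a clear order, and compound 3 is the weakest of the three, with both of its steps beyond the scatter. The 1-hydroxyethyl and 3-aminopropyl groups each count one hydrogen-bond donor and one acceptor, so these counts alone do not match the numbers here, and nothing on hand explains the difference.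

From the compounds shown here alone, the step from compound 2 to compound 3 changes the chain and swaps a hydroxyl for an amine at once, so the share of each stays open; a 3-hydroxypropyl group, with the longer chain but the oxygen kept, would bear on that. Going by these compounds, whether a shorter aminomethyl or 2-aminoethyl group, or a chain ending in a carboxylic acid, would behave like 3-aminopropyl also remains open.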